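A few compounds are considered here, and "the series" means these few. Any claim that something is new, unique, unknown or untested is made for them only; others in the source may bear on it.

Working notes on the series. All four compounds share one core and differ at the saturated ring carbon or on the aryl attached there. Compound 1 `c1ccc(C2CC(c3ccc4c(c3)OCCO4)=NN2c2ccccc2)cc1` gives 22400 nM in a functional assay on WM 266-4 cells (Homo sapiens) for antiproliferative activity, read by MTT assay, with a stated time of 24 h; on this read-out lower numbers stand for stronger inhibition of growth and higher numbers for weaker inhibition of growth. Compound 2 `Clc1cccc(C2CC(c3ccc4c(c3)OCCO4)=NN2c2ccccc2)c1` gives 1750 nM in this assay, the lowest of the two numbers shown, with compound 1 as its nearest neighbour. For compound 3 `c1ccc(N2N=C(c3ccc4c(c3)OCCO4)CC2c2cccc3ccccc23)cc1` the this assay reports > 100000 nM, which is a limit of the assay and not a number (the limit of > 100000 nM in this assay, at which 1 of the 3 values shown sits). The measured steps: a 13-fold lower number from compound 1 to compound 2 (1.11 log units; beyond the scatter); an at least 4.4-fold higher number from compound 1 to compound 3 (0.64 log units; beyond the scatter); an at least 57-fold higher number from compound 2 to compound 3 (1.75 log units; beyond the scatter).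

Compound 4 `c1ccc(COc2cccc(C3CC(c4ccc5c(c4)OCCO5)=NN3c3ccccc3)c2)cc1` differs from compound 2 by benzyloxy in place of chloro on an aromatic carbon. The step from compound 1 to compound 2 shows chloro at this aromatic carbon lowering the number, whereas compound 3 shows that a further aromatic ring on the saturated ring carbon drives the number to the limit. Among the compounds with values here, the entering benzyloxy also brings an aromatic ring, though at a different place; no measured step matches it directly. A step upward in this assay is therefore expected, of modest to large size. Compound 4 is estimated at 10000 nM, within 2500 nM to 60000 nM, which would mean a 5.7-fold higher number from compound 2 to compound 4 (0.76 log units; beyond the scatter).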

Compound 4, concentration for 50% growth inhibition: 870 nM
For compound 4 the middle estimate is 11-fold (1.06 log units) above the measured one, outside the stated range (below it).
By their numbers in this assay, from the lowest: compounds 4 and 2 (each within the scatter of the next); then compound 1. At a limit, above all of these: compound 3.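

The aromatic carbon that carries chloro in compound 2 also takes benzyloxy in this assay, with a 2.0-fold lower number from compound 2 to compound 4 (0.30 log units; within the scatter) and thus no separation between the two groups. Against the hydrogen of compound 1 the lowering persists, with a 26-fold lower number from compound 1 to compound 4 (1.41 log units; beyond the scatter) as the step, so this position accepts a much larger group than chloro. An added aromatic ring therefore does not by itself raise the number: at this place compound 4 stays low, unlike the naphthalen-1-yl change on the saturated ring carbon in compound 3.

Open, as far as these compounds go, is whether an amine, a carboxylic acid or a longer alkyl chain at this aromatic carbon would hold the number, and whether the oxygen or the ring of benzyloxy matters more. No measurement shown gives a cause for chloro and benzyloxy lying together.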